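Adding a hydroxy group to compound 3

The source may report more compounds than this note shows. Statements on the series, on what has been measured and on what is new or still open speak of the compounds shown alone.

Three compounds share one core and differ only in the group carried on the outer aromatic ring. Compound 1 `Cc1c(/N=C/c2ccc(N(C)C)cc2)c(=O)n(-c2ccccc2)n1C` carries a dimethylamino group there, compound 2 `COc1ccc(/C=N/c2c(C)n(C)n(-c3ccccc3)c2=O)cc1` a methoxy group, and compound 3 `Cc1c(/N=C/c2ccccc2)c(=O)n(-c2ccccc2)n1C` a plain hydrogen. In a functional assay on DLD-1 cells (Homo sapiens) for cytotoxicity, read by MTT assay, with a stated time of 72 h (a higher number here means a weaker inhibitor, a lower number a stronger inhibitor), compound 1 gives 871000000 nM, compound 2 gives 977000000 nM, and compound 3 gives 933000000 nM. Compound 3 holds the second highest of the three numbers, but its neighbours sit very close: the step of a 1.0-fold lower number from compound 2 to compound 3 (0.02 log units; within the scatter) and the step of a 1.1-fold higher number from compound 1 to compound 3 (0.03 log units; within the scatter) both fall inside the scatter of repeated measurements, so the three numbers cannot be told apart.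

Compound 4 `Cc1c(/N=C/c2ccc(O)cc2)c(=O)n(-c2ccccc2)n1C` has not yet been measured. It differs from compound 3 by a single change: hydroxy in place of hydrogen on an aromatic carbon. The two steps that already touch this position, from compound 1 and from compound 2 to compound 3, did not move the number beyond the scatter, so there is no basis for expecting the hydroxy group to behave differently. The expected step of a 1.0-fold lower number from compound 3 to compound 4 (0.00 log units; within the scatter) is therefore one of no real change. Compound 4 is estimated to give 930000000 nM in this assay, with a plausible range from 450000000 nM to 1900000000 nM.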

Compound 4, half-maximal inhibitory concentration: 646000000 nM
The estimate for compound 4 lay 1.4-fold (0.16 log units) above the measured number, and the stated range covers the measured number.
By their numbers in this assay, from the lowest: compounds 4, 1, 3 and 2 (each within the scatter of the next).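

The position para to a large group now holds four different groups in this assay, and the hydroxy group adds a hydrogen-bond donor there without a step that can be told from the scatter: a 1.4-fold lower number from compound 3 to compound 4 (0.16 log units; within the scatter) when it replaces hydrogen, a 1.5-fold lower number from compound 2 to compound 4 (0.18 log units; within the scatter) when hydrogen replaces the methyl on the oxygen of the methoxy group, and a 1.3-fold lower number from compound 1 to compound 4 (0.13 log units; within the scatter) when hydroxy replaces dimethylamino. Going by these compounds alone, none of the earlier compounds carried a hydrogen-bond donor on this carbon, so this is the first sign that adding one does not clearly separate a compound from the others. All four compounds therefore read as one group, and the small differences among their numbers should not be taken as a ranking. No measurement shown here offers an explanation for this flat result.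

From the compounds shown here alone, it remains open whether a carboxylic acid, a chlorine atom or a longer chain such as butoxy at this same position would give a step beyond the scatter. The compounds shown also leave open what a change elsewhere on the shared core would do, since all four differ only on the outer aromatic ring.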